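Swapping a benzyl group for a methylphenyl group

A few compounds are considered here, and "the series" means these few. Any claim that something is new, unique, unknown or untested is made for them only; others in the source may bear on it.

Growth inhibition measured in a functional assay on Jurkat cells (Homo sapiens) for inhibition, read by CCK-8 assay, with a stated time of 48 h; on this read-out higher numbers stand for weaker inhibition of growth and lower numbers for stronger inhibition of growth:
Compound 1 (`Cc1ccccc1Nc1nc(Nc2cccnc2)ncc1Cl`) gives 38600 nM
Compound 2 (`CCN1CCN(c2ccc(Nc3ncc(Cl)c(Nc4ccccc4C)n3)nc2)CC1`) gives > 100000 nM (a limit of the assay, not a number)
Compound 3 (`CN1CCN(c2ccc(Nc3ncc(Cl)c(NCc4ccc(C(F)(F)F)cc4)n3)nc2)CC1`) gives 7960 nM

Only two of these results are true numbers. Of those two, compound 3 has the lower at 7960 nM and so the stronger inhibition of growth, and its gap to compound 1 lies beyond the scatter of repeated measurements.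

In compound 4 (`Cc1cccc(Nc2nc(Nc3ccc(N4CCN(C)CC4)cn3)ncc2Cl)c1`), 3-methylphenyl takes the place of 4-(trifluoromethyl)benzyl on a nitrogen on an aromatic ring (3-methylphenyl in place of 4-(trifluoromethyl)benzyl on a nitrogen on an aromatic ring). Within the data shown here, no pair of measured compounds isolates this change, so any forecast is indirect. A rise towards weaker inhibition is expected on the evidence of compound 1 at 38600 nM which also carries a methylphenyl group. Compound 2 carries one too, and its result is a limit. The expected change in this assay is a 3.1-fold higher number from compound 3 to compound 4 (0.50 log units; beyond the scatter) towards a higher number. Compound 4 is estimated at 25000 nM (expected range 6000 nM to 100000 nM).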

Compound 4, concentration for 50% growth inhibition: 15300 nM
The estimate for compound 4 lay 1.6-fold (0.21 log units) above the measured number; low and high end bracket the measured number.
By their numbers in this assay, from the lowest: compounds 3 and 4 (each within the scatter of the next); then compound 1. At a limit, above all of these: compound 2.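

In this assay, among these compounds, compound 3 and compound 4 share everything except the group on a nitrogen on an aromatic ring, making this the first pair that isolates that place: a 1.9-fold higher number from compound 3 to compound 4 (0.28 log units; within the scatter). The two groups therefore cannot be told apart on this read-out, even though 3-methylphenyl is the smaller group and carries no fluorine. Nothing measured here offers a reason for this result.

This single swap alters the carbon link of the benzyl group, the substituent on the ring and that substituent's location all at once, so any opposing contributions of these features cannot be separated. Going by these compounds, it remains open whether an unsubstituted benzyl group, or a ring bearing a carboxylic acid or an amine, would give a step beyond the scatter at this nitrogen.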